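Cyano in Place of Sulfamoyl on a Shared Core

A few compounds are considered here, and "the series" means these few. Any claim that something is new, unique, unknown or untested is made for them only; others in the source may bear on it.

Measured so far:
compound 1 `NS(=O)(=O)c1ccc(Nc2nncc3ccccc23)cc1` gives 12 nM in a functional assay on HeLa cells (Homo sapiens) for antiproliferative activity, read by sulforhodamine B assay, with a stated time of 72 h; a lower number here means a stronger inhibitor, a higher number a weaker inhibitor;
compound 2 `O=S(=O)(Nc1ncccn1)c1ccc(Nc2nncc3ccccc23)cc1` gives 14 nM in this assay.

Compound 1 stands lowest of the two numbers, its nearest neighbour being compound 2 with a 1.2-fold higher number from compound 1 to compound 2 (0.07 log units; within the scatter). Compound 3 `N#Cc1ccc(Nc2nncc3ccccc23)cc1` differs from compound 1 by cyano in place of sulfamoyl on an aromatic carbon. For the measured compounds named here, the only measured step, from compound 1 to compound 2, alters the sulfonamide nitrogen and leaves the sulfamoyl itself in place, so it does not bear on the exchange of the whole group for cyano. Going by the values given here, no measured pair speaks to that exchange. With nothing to lean on, compound 3 is expected to land near compound 1, with a modest weakening counted as more likely than a gain, and the expected step is a 2.5-fold higher number from compound 1 to compound 3 (0.40 log units; beyond the scatter). The estimate for compound 3 in this assay is 30 nM, ranging from 8 nM to 120 nM.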

Compound 3, half-maximal inhibitory concentration: 1.5 nM
The estimate for compound 3 lay 20-fold (1.30 log units) above the measured number, and the stated range ends above it.
By their numbers in this assay, from the lowest: compound 3; then compounds 1 and 2 (each within the scatter of the next).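

Exchanging the whole sulfamoyl for cyano on this aromatic carbon, para to a large group, gives an 8.0-fold lower number from compound 1 to compound 3 (0.90 log units; beyond the scatter) in this assay. For the compounds shown here, the earlier step, a 1.2-fold higher number from compound 1 to compound 2 (0.07 log units; within the scatter), altered only the sulfonamide nitrogen and stayed within the scatter, so only this exchange shows that the number responds to the group on this carbon. Compound 3 also shows that the sulfamoyl, with its hydrogen-bond donor, is not required for a low number on this core, and nothing available explains the change.

The compounds shown leave open whether the lower number belongs to cyano alone or would also come with another group in this place, such as an amine, a carboxylic acid or a chlorine atom. They also leave open whether the same exchange would have a similar effect on a changed core.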